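Lengthening a methyl to ethyl on a shared core

The source may hold more compounds than are shown below. What is called first, only, known or untested is meant among the compounds shown, and "the series" means these compounds.

Measured compounds:
compound 1 `Cc1cc(Cl)c2oc(N3CCN(C)CC3)nc2c1` gives 0.26;
compound 2 `CCc1cccc2nc(N3CCN(C)CC3)oc12` gives 0.15;
compound 3 `Cc1cc(C)c2oc(N3CCN(C)CC3)nc2c1` gives 0.62.

In an assay on ileum (strain Hartley) with 5-hydroxytryptamine receptor 3A (Cavia porcellus) as the target (on this read-out lower numbers stand for smaller maximal responses and higher numbers for larger maximal responses), compound 3 stands highest of the three, with compound 1 next and compound 2 furthest down. Among the compounds with values here, the one step known within this set, a number 0.36 higher from compound 1 to compound 3 (beyond the scatter), concerns a different change from the one now considered. Compound 4 `CCc1cc(C)cc2nc(N3CCN(C)CC3)oc12` differs from compound 3 by methyl in place of hydrogen on a saturated chain carbon bound to an aromatic carbon. Within the data shown here, no measured step tells how this change acts; compound 2, which carries an ethyl group, gives the lowest value, but it also differs from compound 3 elsewhere, so its number alone cannot settle the matter. A step of modest size is therefore expected, a number 0.14 lower from compound 3 to compound 4 (beyond the scatter), likely downward. Compound 4 is estimated at 0.48, within 0.28 to 0.68.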

Compound 4, intrinsic activity: the largest response reached, as a fraction of the reference agonist's: 0.26
Compound 4: the middle estimate sits 0.22 above what was measured, and the stated range ends above it.
By their numbers in this assay, from the lowest: compound 2; then compounds 1 and 4 (each within the scatter of the next); then compound 3.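

In this assay, lengthening methyl to ethyl on a saturated chain carbon bound to an aromatic carbon now has a direct reading: a number 0.36 lower from compound 3 to compound 4 (beyond the scatter), a large fall from one added carbon. With the ethyl group already in place, an added methyl gives a number 0.11 higher from compound 2 to compound 4 (beyond the scatter), while exchanging chloro for ethyl gives no change at the digits printed from compound 1 to compound 4 (within the scatter). Nothing available here bears on the reason for these results. Going by these compounds, whether a longer chain such as propyl would lower the maximal response further remains open. So does the effect of a methoxy group at this place.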